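The source may report more compounds than this note shows. Statements on the series, on what has been measured and on what is new or still open speak of the compounds shown alone.

Compound 1 `COc1ccc(C(=O)/C=C/c2cc(-c3cc(OC)c(OC)c(OC)c3)n[nH]2)cc1OC` is tested in a functional assay on U-251 cells (Homo sapiens) for cytotoxicity, read by sulforhodamine B assay, with a stated time of 48 h, tested at 1 uM (a lower number here means a stronger effect, a higher number a weaker effect of the compound at the concentration tested), where compound 1 gives 65%, the lowest of the two numbers recorded. For the measured compounds named here, its only measured neighbour is compound 2 `COc1cc(-c2cc(/C=C/C(=O)c3ccc(F)c(F)c3)[nH]n2)cc(OC)c1OC`, which in this assay gives 87%, a step of a number 22 percentage points higher from compound 1 to compound 2 (beyond the scatter). Compound 3 `COc1cc(C(=O)/C=C/c2cc(-c3cc(OC)c(OC)c(OC)c3)n[nH]2)cc(OC)c1OC` differs from compound 1 by methoxy in place of hydrogen on an aromatic carbon. Going by the values given here, no measured step covers this change; the step to compound 2 concerns a different replacement at the same place and does not transfer. Compound 3 is therefore expected to move by a number 5 percentage points lower from compound 1 to compound 3 (within the scatter), a shift not beyond the scatter, and is estimated at 60% within 35% to 85%.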

Compound 3, a percentage reported as activity, at one concentration (the size of the read-out at that concentration, not a potency): 83%
The estimate for compound 3 lay 23 percentage points below the measured number; the measured number falls inside the stated range.
By their numbers in this assay, from the lowest: compound 1; then compounds 3 and 2 (each within the scatter of the next).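

Placing a methoxy on this aromatic carbon, ortho to a methoxy group, gives in this assay a number 18 percentage points higher from compound 1 to compound 3 (beyond the scatter) and so weakens the effect at the concentration tested. For the compounds shown here, the earlier step showed only that replacing both methoxy groups of compound 1 with fluorines weakens the effect; this one shows that the ring also responds to a single added group at an otherwise unsubstituted carbon. Nothing available explains this shift. From the compounds shown here alone, it remains open how a hydroxyl, an amine or a chlorine at this same carbon would compare with hydrogen and methoxy. Going by these compounds, whether a longer alkoxy chain there would weaken the effect further also remains open.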